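Replacing Trifluoromethyl with Isopropyl in Compound 3

The compounds below may be only part of what the source reports. "The series", "measured", "known", "first", "only" and "open" are said of these compounds alone.

In a physicochemical assay for acid dissociation, using potentiometric titration, compound 3 `CCC/N=C1\S/C(=C\c2ccc(O)c(C(F)(F)F)c2)C(=O)N1c1ccccc1C` gives 6.6 as the lowest of the three numbers measured. Compound 1 `CCC/N=C1\S/C(=C\c2ccc(O)cn2)C(=O)N1c1ccccc1C` stands at 7.1 and compound 2 `CCC/N=C1\S/C(=C\c2ccc(O)cc2)C(=O)N1c1ccccc1C` at 8.3 on the same scale. The change to compound 4 `CCC/N=C1\S/C(=C\c2ccc(O)c(C(C)C)c2)C(=O)N1c1ccccc1C` is isopropyl in place of trifluoromethyl on an aromatic carbon ortho to a hydroxy group. The step that bears most on it is the large one a number 1.70 log units lower from compound 2 to compound 3 (beyond the scatter) with trifluoromethyl in place of hydrogen on that carbon. The other large step of a number 1.20 log units higher from compound 1 to compound 2 (beyond the scatter) lies elsewhere in the structure and says less. Among the measured compounds shown here, no measured compound carries isopropyl, so compound 2 at 8.3 serves as the guide. A large upward step is expected, a number 1.90 log units higher from compound 3 to compound 4 (beyond the scatter) in this assay by this reasoning. For compound 4 the estimate is 8.5 with 8 to 9 as the expected range.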

Compound 4, acid dissociation constant: 8.6
Beside the measured number, compound 4's estimate is 0.10 log units below it; the measured number falls inside the stated range.
By their numbers in this assay, from the lowest: compound 3; then compound 1; then compounds 2 and 4 (each within the scatter of the next).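

In this assay isopropyl in place of trifluoromethyl on this carbon, ortho to a hydroxy group, gives a number 2.00 log units higher from compound 3 to compound 4 (beyond the scatter) and so undoes the whole drop seen with trifluoromethyl. Isopropyl in place of hydrogen gives a number 0.30 log units higher from compound 2 to compound 4 (within the scatter) and so leaves the number where hydrogen had it. Of the three groups seen on this carbon, trifluoromethyl alone moves the number. Nothing shown here explains this. From the compounds shown here alone, whether a nitrile, a methoxy group or a chlorine atom on this carbon would behave like isopropyl or like trifluoromethyl remains open.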